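Swapping a Chlorophenyl for a Difluorophenyl on Two Cores

The source may hold more compounds than are shown below. What is called first, only, known or untested is meant among the compounds shown, and "the series" means these compounds.

Compound 1 `CC1CCN(c2c(S(=O)(=O)c3cccc(Cl)c3)cnc3cc(Cl)ccc23)CC1` carries a 3-chlorophenyl on a sulfonyl sulfur. In an assay on isolated protein for displacement of a labelled ligand from metabotropic glutamate receptor 5 (Homo sapiens), with a stated time of 60 min, tested at 1 uM (on this read-out higher numbers stand for more inhibition at the one concentration tested (going by the name of the read-out) and lower numbers for less inhibition), compound 1 gives 92%. Compound 2 `CC1CCN(c2c(S(=O)(=O)c3ccc(F)c(F)c3)cnc3cc(Cl)ccc23)CC1` differs from it in one place only, namely (3,4-difluorophenyl in place of 3-chlorophenyl on a sulfonyl sulfur). In this assay compound 2 gives 90%, so this change made a number 2 percentage points lower from compound 1 to compound 2 (within the scatter).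

Compound 3 `CC1CCN(c2c(S(=O)(=O)c3cccc(Cl)c3)cnc3ccc(F)cc23)CC1` keeps the 3-chlorophenyl on the sulfonyl sulfur but carries it on the core of compound 3; how that core differs from the core of compound 1 is not broken down here. In this assay compound 3 gives 92%, level with compound 1 at the digits given, and the two values lie within the scatter of each other.

Compound 4 `CC1CCN(c2c(S(=O)(=O)c3ccc(F)c(F)c3)cnc3ccc(F)cc23)CC1` has not yet been measured. It differs from compound 3 by 3,4-difluorophenyl in place of 3-chlorophenyl on a sulfonyl sulfur, the same change as that from compound 1 to compound 2, made at the same place; among the compounds shown this change occurs twice. Because the earlier change made a number 2 percentage points lower from compound 1 to compound 2 (within the scatter), the step from compound 3 to compound 4 is expected to be similarly small, estimated as a number 2 percentage points lower from compound 3 to compound 4 (within the scatter). Compound 4 is therefore expected to give about 90% in this assay, with a likely range from 83% to 96%. That expectation rests on a single earlier pair, and the effect of the change of core on its own has not been separated out.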

Compound 4, a percentage reported as inhibition, at one concentration (the size of the read-out at that concentration, not a potency): 82%
Compound 4: the middle estimate sits 8 percentage points above what was measured; the whole stated range lies above it.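

Setting 3,4-difluorophenyl in place of 3-chlorophenyl on the core of compound 3 gives a number 10 percentage points lower from compound 3 to compound 4 (within the scatter) in this assay, and this step can be set beside the same change made on the core of compound 1: the same change on two cores in this assay, a number 2 percentage points lower (within the scatter) from compound 1 to compound 2 and a number 10 percentage points lower (within the scatter) from compound 3 to compound 4, 8 percentage points apart, within the scatter of two such steps. Although the two printed steps are not the same number, repeated measurements of this kind could produce a gap of that size, so these four compounds give no sign that the change behaves differently on the two cores. Going by these compounds alone, this does not prove that the change carries over unaltered, since only two pairs are available and a modest dependence on the core could be hidden within the scatter; a percentage at one concentration is also not a potency, so the compounds could still differ in a way this read-out does not capture.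

The compounds shown leave open what happens on these two cores when the group on the sulfonyl sulfur is a plain phenyl or a phenyl carrying a methoxy group or a nitrile. They also leave open whether the change would behave the same way on a third core, or in a full concentration series rather than at one concentration.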